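Adding a Methyl to the Piperidine Ring of Compound 3

This account rests on a few compounds, and the source may have more. Where it says the series, first, only, none or still open, it means among the compounds named here.

Measured so far:
Compound 1, `C=CCc1cc(-c2ccc(O)c(CC=C)c2)c(O)c(C(c2ccccc2)N2CCC(C)CC2)c1`, 25.8%
Compound 2, `C=CCc1cc(-c2ccc(O)c(CC=C)c2)c(O)c(C(c2ccc(Cl)cc2)N2CCCC2)c1`, 40.6%
Compound 3, `C=CCc1cc(-c2ccc(O)c(CC=C)c2)c(O)c(C(c2ccc(Cl)cc2)N2CCCCC2)c1`, 45%

All three compounds share one core and were tested in an assay on isolated protein for inhibition of Maltase-glucoamylase (Homo sapiens), with stated times of 15 min and 10 min, tested at 64 uM; on this read-out higher numbers stand for more inhibition at the one concentration tested (going by the name of the read-out) and lower numbers for less inhibition. Compound 3 gives the highest of the three numbers, 45%. Compound 2 is nearest, and its number is within the scatter of that of compound 3, so the two cannot be ranked. Compound 1 is furthest, and its lower number lies beyond the scatter.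

Compound 4, `C=CCc1cc(-c2ccc(O)c(CC=C)c2)c(O)c(C(c2ccc(Cl)cc2)N2CCC(C)CC2)c1`, is not yet measured. It differs from compound 3 in one place: methyl in place of hydrogen on a saturated ring carbon.

Among the compounds with values here, only one measured step is a single change, a number 4.4 percentage points higher from compound 2 to compound 3 (within the scatter), and it concerns a change of ring size, not the present one. Within the data shown here, no step tests a methyl on this ring. Compound 1 carries the same methyl-bearing ring but with a different aromatic group, so its lower number cannot be tied to the methyl alone. The expectation is therefore a step of no clear direction and within the scatter, a number 3 percentage points lower from compound 3 to compound 4 (within the scatter). Compound 4 is estimated to give 42%, in the range 28% to 56%.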

Compound 4, a percentage reported as inhibition, at one concentration (the size of the read-out at that concentration, not a potency): 8.6%
Compound 4: the middle estimate sits 33.4 percentage points above what was measured; the measured number lies below the stated range.
By their numbers in this assay, from the lowest: compound 4; then compound 1; then compounds 2 and 3 (each within the scatter of the next).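

In this assay, the ring is sensitive to a very small addition: methyl on the saturated ring carbon three ring bonds from the ring nitrogen gives a number 36.4 percentage points lower from compound 3 to compound 4 (beyond the scatter) and stands in contrast to the change of ring size, a number 4.4 percentage points higher from compound 2 to compound 3 (within the scatter), which lay within the scatter. Measured against the pyrrolidin-1-yl ring, the 4-methylpiperidin-1-yl ring gives a number 32 percentage points lower from compound 2 to compound 4 (beyond the scatter), and with that methyl-bearing ring in both compounds, chloro in place of hydrogen on an aromatic carbon gives a number 17.2 percentage points lower from compound 1 to compound 4 (beyond the scatter), so the chloro does not restore inhibition with this ring. The data shown offer no measurement that explains the loss of inhibition on adding the methyl.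

As far as these compounds go, it remains open whether a hydroxyl group or an ethyl group on the same ring carbon would behave like methyl. Each number also comes from one concentration, so the ranking of these compounds by potency is still unknown.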